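The compounds below may be only part of what the source reports. "The series", "measured", "known", "first", "only" and "open" are said of these compounds alone.

In a functional assay on K562 cells (Homo sapiens) for antiproliferative activity, read by CCK-8 assay, with a stated time of 24 h (on this read-out higher numbers stand for weaker inhibition and lower numbers for stronger inhibition), compound 1 `Cc1ccc(NC(=O)c2ccc(CN3CCCN(C)CC3)cc2)cc1-n1cc(-c2cnc3ccnn3c2)cn1` gives 5880 nM. Compound 2 `Cc1ccc(NC(=O)c2cccc(C(F)(F)F)c2)cc1-n1cc(-c2cnc3cccnn23)cn1` gives < 2 nM, which is a limit of the assay and not a number. From the compounds shown here alone, of the two results, this is the one at the low-number end, but its exact position is unknown.

Compound 3 `Cc1ccc(NC(=O)c2ccc(F)cc2)cc1-n1cc(-c2cnc3cccnn23)cn1` has 4-fluorophenyl in place of 3-(trifluoromethyl)phenyl on a carbonyl carbon. For the measured compounds named here, the series contains no measured step for this exchange, so the expectation is loosely founded. A shift towards a higher number in this assay, meaning weaker inhibition, is expected, and a shift beyond the usual scatter is more likely than none. With compound 2 at its limit of < 2 nM, the expected direction is upward, since little room remains for a lower reading. The estimated change is an at least 20-fold higher number from compound 2 to compound 3 (1.30 log units; beyond the scatter), and its size is uncertain because the starting point is only a limit. For compound 3, the expected value is 40 nM, with an estimated range of 3 nM to 500 nM.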

Compound 3, half-maximal inhibitory concentration: 12400 nM
Compound 3: the middle estimate sits 310-fold (2.49 log units) below what was measured; the measured number lies above the stated range.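

In this assay, for the compounds shown here, the exchange of 3-(trifluoromethyl)phenyl for 4-fluorophenyl on a carbonyl carbon gives an at least 6200-fold higher number from compound 2 to compound 3 (3.79 log units; beyond the scatter) and is the first step that differs in one place. With the rest of the structure held constant, the result shows that activity in this pair depends strongly on the group at this position, and that the two substituted phenyl groups are far from interchangeable there. The size of the step is only a lower bound because the value for compound 2 is a limit of the assay and not a number: the limit of < 2 nM in this assay, at which 1 of the 3 values shown sits.

The pair does not separate the change from trifluoromethyl to fluorine from the change between the 3- and 4- labels in the group names; a 3-fluorophenyl or a 4-(trifluoromethyl)phenyl group would be needed to tell these apart. From the compounds shown here alone, how a nitrile or a carboxylic acid on that phenyl ring would read in this assay also stays open, and compound 1 differs from both other compounds in more than one place, which leaves it without a readable step.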